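A methyl group added to compound 3

The source may report more compounds than this note shows. Statements on the series, on what has been measured and on what is new or still open speak of the compounds shown alone.

Measured in a functional assay on K562 cells (Homo sapiens) for inhibition, read by trypan blue exclusion, with a stated time of 24 h, tested at 10 uM; on this read-out higher numbers stand for more inhibition of growth at the one concentration tested and lower numbers for less inhibition of growth:
Compound 1 `Cc1ccc(OCC(=O)Nc2ccccc2C(N)=O)cc1`: < 10%, a limit of the assay
Compound 2 `Cc1ccc(OCC(=O)Nc2ccc(Cl)cc2C(N)=O)cc1`: 24.1%
Compound 3 `NC(=O)c1cc(I)ccc1NC(=O)COc1ccccc1`: 73%

Compound 3, at 73%, holds the higher of the two actual numbers in this assay. Compound 4 `Cc1ccc(OCC(=O)Nc2ccc(I)cc2C(N)=O)cc1` differs from it by methyl in place of hydrogen on an aromatic carbon. Within the data shown here, the only measured step, a number at least 14.1 percentage points higher from compound 1 to compound 2 (beyond the scatter), is chloro in place of hydrogen, a different change, so it sets no direct size here. Compound 2 already carries the 4-methylphenyl and gives 24.1%, but it also differs from compound 4 elsewhere, so this is only a weak hint of a loss. A modest fall is therefore expected, a number 13 percentage points lower from compound 3 to compound 4 (beyond the scatter). For compound 4 the estimate is 60%, with an expected range of 35% to 85%.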

Compound 4, percent growth inhibition at one concentration: 49.8%
For compound 4 the middle estimate is 10.2 percentage points above the measured one; measured number inside the range.
By their numbers in this assay, from the lowest: compound 2; then compound 4; then compound 3. At a limit, below all of these: compound 1.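

In this assay, the change from phenyl to 4-methylphenyl lowers growth inhibition when iodo is present: a number 23.2 percentage points lower from compound 3 to compound 4 (beyond the scatter). With the 4-methylphenyl kept, iodo still improves on chloro, a number 25.7 percentage points higher from compound 2 to compound 4 (beyond the scatter), and on hydrogen, a number at least 39.8 percentage points higher from compound 1 to compound 4 (beyond the scatter). The second of these steps starts from a limit for compound 1, not a number: the limit of < 10% in this assay, at which 1 of the 4 values shown sits.

On these data alone, whether the methyl has a similar effect with chloro or hydrogen in place of iodo remains open. So does whether a methoxy, an ethyl or a fluoro on that carbon would act as the methyl does.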